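Removing the fluoro from compound 3

This account rests on a few compounds, and the source may have more. Where it says the series, first, only, none or still open, it means among the compounds named here.

Compound 1 `COc1cccc(N2CCN(C(=O)C(C)N3C(=O)CCC3=O)CC2)c1`: 75%
Compound 2 `CC(C(=O)N1CCN(c2cccc(Cl)c2)CC1)N1C(=O)CCC1=O`: 75%
Compound 3 `CC(C(=O)N1CCN(c2ccccc2F)CC1)N1C(=O)CCC1=O`: 100%

Three compounds built on a shared core were tested in a functional assay on the whole organism (strain Swiss) with Mus musculus as the target, in the maximal electroshock model, with a stated time of 0.25 h, at a dose of 300 mg/kg by the intraperitoneal route; a higher number here means a stronger effect of the compound at the dose given, a lower number a weaker effect. Compound 1 and compound 2 sit at the same level, as the step of no change at the digits printed from compound 1 to compound 2 (within the scatter) shows. Compound 3 stands highest of the three: the step of a number 25 percentage points higher from compound 1 to compound 3 (beyond the scatter) and the step of a number 25 percentage points higher from compound 2 to compound 3 (beyond the scatter) both lift the read-out beyond the scatter, so compound 3 is the most active of the measured set.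

The next compound, compound 4 `CC(C(=O)N1CCN(c2ccccc2)CC1)N1C(=O)CCC1=O`, has not yet been measured in this assay. It differs from compound 3 in one place: hydrogen in place of fluoro on an aromatic carbon.

Going by the values given here, no measured step removes a fluoro on its own. The two steps that lead into compound 3, a number 25 percentage points higher from compound 1 to compound 3 (beyond the scatter) and a number 25 percentage points higher from compound 2 to compound 3 (beyond the scatter), each exchange the whole aryl group, so they only show that the 2-fluorophenyl group sits above the other two aryl groups tried, not how much of that rests on the fluoro itself. A modest fall or no change beyond the scatter therefore seems most likely for compound 4, and a step of a number 15 percentage points lower from compound 3 to compound 4 (beyond the scatter) is expected. Compound 4 is estimated at 85%, within 60% to 100%.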

Compound 4, a percentage reported as activity, at one dose (the size of the read-out at that dose, not a potency): 100%
For compound 4 the middle estimate is 15 percentage points below the measured one; the measured number falls inside the stated range.
By their numbers in this assay, from the lowest: compounds 1 and 2 (each within the scatter of the next); then compounds 3 and 4 (each within the scatter of the next).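

In this assay, hydrogen in place of fluoro on this aromatic carbon, ortho to a large group, gives no change at the digits printed from compound 3 to compound 4 (within the scatter), so the fluoro is not needed to hold the read-out at this dose. The plain phenyl group also stands clear of the two other aryl groups, with a number 25 percentage points higher from compound 2 to compound 4 (beyond the scatter) and a number 25 percentage points higher from compound 1 to compound 4 (beyond the scatter), so the gap that earlier seemed to favour 2-fluorophenyl does not depend on the fluoro, and the chloro and methoxy compounds read lower than the compound carrying hydrogen. No measurement offered here bears on why the read-out holds when the fluoro leaves.

Going by these compounds, it remains open whether a methyl, a trifluoromethyl or a hydroxyl group on this same aromatic carbon would keep the read-out of compound 3 and compound 4 or lower it, as the chloro and methoxy compounds, which carry their groups elsewhere on the ring, leave that place untested. Since the read-out gives the size of the effect at one dose and not a potency, whether compound 3 and compound 4 would also match at smaller doses also stays unanswered.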